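The source may report more compounds than this note shows. Statements on the series, on what has been measured and on what is new or still open speak of the compounds shown alone.

In an ADME assay on L929 cells (Mus musculus) for cytotoxicity, read by resazurin assay, with a stated time of 48 h (a lower number here means that less compound is tolerated, a higher number that more compound is tolerated), compound 1 (`COC(=O)COc1c2cc([N+](=O)[O-])ccc2nn1Cc1ccccc1`) gives > 256000 nM, which is a limit. Compound 2 (`COC(=O)CCOc1c2cc([N+](=O)[O-])ccc2nn1Cc1ccccc1`) gives > 256000 nM, also a limit. Compound 3 (`O=[N+]([O-])c1ccc2nn(Cc3ccccc3)c(OCCO)c2c1`) gives > 256000 nM, again a limit, so its place in the series is known only as a limit and not as a number.

Compound 4 (`O=[N+]([O-])c1ccc2nn(Cc3ccccc3)c(OCCCO)c2c1`) differs from compound 3 by hydroxymethyl in place of hydroxy on a saturated chain carbon, two bonds along the chain from an oxygen on an aromatic ring, or 2-hydroxyethoxy to 3-hydroxypropoxy.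

The measured steps that bear on this change are a step that the two limits leave unreadable from compound 1 to compound 3, a step that the two limits leave unreadable from compound 2 to compound 3 and a step that the two limits leave unreadable from compound 1 to compound 2. None of them has a readable size.

No step beyond the scatter is expected in this assay because of the limit of > 256000 nM in this assay, at which 3 of the 3 values shown sit. The expected change is a step that the limit leaves unreadable from compound 3 to compound 4. For compound 4 the estimate is 280000 nM, with an expected range of 150000 nM to 500000 nM.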

Compound 4, concentration lethal to 50% of the cells: > 256000 nM
Compound 4: a limit, no number; the forecaster's own chance of this, stated with the estimate: 80%; the middle value lies beyond the limit too.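

In this assay compound 4 gives > 256000 nM, a limit, so the steps to compound 4 from compound 1, compound 2 and compound 3 cannot be read. As far as these compounds go, whether these four compounds differ at all in this assay, and in what order, stays open.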